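This account rests on a few compounds, and the source may have more. Where it says the series, first, only, none or still open, it means among the compounds named here.

Compound 1, `c1ccc(COc2ccc(OCCOCCNc3cc[nH]c3)cc2)cc1`, gives 11300 nM in a functional assay on SK-OV-3 cells (Homo sapiens) for inhibition, read by CCK-8 assay, with a stated time of 70 h; a lower number here means a stronger inhibitor, a higher number a weaker inhibitor. Compound 2, `COC(=O)c1ccc(COc2ccc(OCCOCCNC3CCCC3)cc2)cc1`, gives 6990 nM. Compound 3, `c1ccc(COc2ccc(COc3ccc(OCCOCCNC4CCCC4)cc3)cc2)cc1`, gives 10000 nM.

Among these three numbers compound 2 has the lowest, but its gaps to compound 3 and to compound 1 both fall within the usual scatter, so none of the three can be called stronger or weaker than another.

Compound 4 is `O=[N+]([O-])c1cccc(COc2ccc(OCCOCCNC3CCCC3)cc2)c1`. It differs from compound 2 in one place: 3-nitrophenyl in place of 4-(methoxycarbonyl)phenyl on a saturated chain carbon bound to an oxygen on an aromatic ring.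

Among the compounds with values here, one measured step touches the same position. Replacing the group on that chain carbon gave a 1.4-fold higher number from compound 2 to compound 3 (0.16 log units; within the scatter). Compound 1 also carries a different group there, but it is built differently elsewhere, so only its value can be compared, and that value too sits within the scatter of compound 2. The data therefore give no sign that a change at this position moves the number beyond the scatter.

For compound 4 the expectation is a step of a 1.1-fold higher number from compound 2 to compound 4 (0.03 log units; within the scatter), essentially none. The estimated value for compound 4 is 7500 nM, with a range from 3000 nM to 18000 nM.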

Compound 4, half-maximal inhibitory concentration: 15400 nM
Compound 4: the middle estimate sits 2.1-fold (0.31 log units) below what was measured, within the range that was stated.
By their numbers in this assay, from the lowest: compounds 2, 3, 1 and 4 (each within the scatter of the next, the first and the last beyond it).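

In this assay, within the data shown here, the swap to 3-nitrophenyl gives a 2.2-fold higher number from compound 2 to compound 4 (0.34 log units; beyond the scatter), the first change on this saturated chain carbon bound to an oxygen on an aromatic ring that lies beyond the scatter, though the step is modest. The position is therefore not wholly indifferent to the group it carries, something that a 1.4-fold higher number from compound 2 to compound 3 (0.16 log units; within the scatter) could not show. The two groups have the same counts of hydrogen-bond donors and acceptors and the same net charge, so those counts do not separate them, and no measurement here explains the step.

The step changes both the group on the phenyl ring and its numbered place, and the compounds shown do not tell these two changes apart. Going by these compounds, how a carboxylic acid or an amine on that phenyl ring would compare also remains open.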